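This account rests on a few compounds, and the source may have more. Where it says the series, first, only, none or still open, it means among the compounds named here.

Compound 1 `CCCS(=O)(=O)Nc1cccc2c1CCC2c1ncc[nH]1` carries a (propylsulfonyl)amino group on an aromatic carbon of the shared core. In a functional assay on CHO cells for agonist activity at Alpha-1A adrenergic receptor (Homo sapiens), read by FLIPR and calcium flux (a higher number here means a larger maximal response, a lower number a smaller maximal response), compound 1 gives 54%, the second highest of the three measured values. Compound 2 `COc1cccc2c1CCC2c1ncc[nH]1` has methoxy at that position and gives 65%, a step of a number 11 percentage points higher from compound 1 to compound 2 (beyond the scatter). Compound 3 `c1cncc(-c2cccc3c2CCC3c2ncc[nH]2)c1` has pyridin-3-yl there and gives 36%, a step of a number 18 percentage points lower from compound 1 to compound 3 (beyond the scatter); between compound 2 and compound 3 the step is a number 29 percentage points lower from compound 2 to compound 3 (beyond the scatter).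

Compound 4 `c1cc(-c2cn[nH]c2)c2c(c1)C(c1ncc[nH]1)CC2` is not yet measured. It differs from compound 1 in this way: 1H-pyrazol-4-yl in place of (propylsulfonyl)amino on an aromatic carbon. The step from compound 1 to compound 3 bears most closely on this change, as it also puts an aromatic ring in place of the (propylsulfonyl)amino group, and it lowered the maximal response by a modest amount beyond the scatter. A decrease of similar size is therefore expected here. Compound 4 is estimated to give 40% in this assay, within a range from 25% to 56%. That estimate corresponds to an expected step of a number 14 percentage points lower from compound 1 to compound 4 (beyond the scatter).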

Compound 4, largest response reached (Emax), in percent of the reference or control that the assay uses: 84%
Compound 4: the middle estimate sits 44 percentage points below what was measured; the measured number lies above the stated range.
By their numbers in this assay, from the lowest: compound 3; then compound 1; then compound 2; then compound 4.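

At this aromatic carbon, 1H-pyrazol-4-yl gives the largest maximal response of the four compounds in this assay, with a step of a number 30 percentage points higher from compound 1 to compound 4 (beyond the scatter) and one of a number 19 percentage points higher from compound 2 to compound 4 (beyond the scatter) and one of a number 48 percentage points higher from compound 3 to compound 4 (beyond the scatter) in the same direction. An aromatic ring in place of (propylsulfonyl)amino therefore does not lower the response as such: pyridin-3-yl and 1H-pyrazol-4-yl move it in opposite directions from compound 1, so the choice of ring decides the outcome here. Nothing measured here accounts for the gap between these two rings.

The compounds shown leave open whether another five-membered aromatic ring, such as thiazol-5-yl, would also give a high response. They also leave open what 1-methylpyrazol-4-yl, with a methyl group on the ring nitrogen, would give at this carbon.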